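The source may report more compounds than this note shows. Statements on the series, on what has been measured and on what is new or still open speak of the compounds shown alone.

Measured so far:
Compound 1 `CCCCCCCCn1cc(/C=C/C(=O)c2ccc(NC(=O)CN3CCN(c4ccccc4F)CC3)cc2)nn1`, in a functional assay on A549 cells (Homo sapiens) for inhibition, read by MTT assay (on this read-out higher numbers stand for weaker inhibition and lower numbers for stronger inhibition), compound 1 gives 47100 nM.
Compound 2 `CCCCCCCCCCn1cc(/C=C/C(=O)c2ccc(NC(=O)CN3CCN(c4ccccc4)CC3)cc2)nn1`, in this assay compound 2 gives 52100 nM.
Compound 3 `O=C(CN1CCN(c2ccccc2F)CC1)Nc1ccc(C(=O)/C=C/c2cn(Cc3ccc(Br)cc3)nn2)cc1`, in this assay compound 3 gives 14700 nM.

Compound 3 has the lowest of the three numbers; it lies a 3.2-fold lower number from compound 1 to compound 3 (0.51 log units; beyond the scatter), and its gap to compound 2 is of similar size and likewise beyond the scatter. Compound 4 `O=C(CN1CCN(c2ccccc2)CC1)Nc1ccc(C(=O)/C=C/c2cn(Cc3ccc(Br)cc3)nn2)cc1` has not been measured. It differs from compound 3 by hydrogen in place of fluoro on an aromatic carbon. For the measured compounds named here, no measured pair shows this change on its own: compound 1 and compound 2 carry the two variants of this ring, but they also differ in the chain on the triazole, so their two values, which sit within the scatter of each other, only hint that the change may be small. Going by the values given here, the one step beyond the scatter, a 3.2-fold lower number from compound 1 to compound 3 (0.51 log units; beyond the scatter), concerns a different part of the molecule. Compound 4 is therefore expected to stay close to compound 3, with a step of a 1.1-fold higher number from compound 3 to compound 4 (0.04 log units; within the scatter) in this assay. The estimate for compound 4 is 16000 nM, ranging from 6000 nM to 40000 nM.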

Compound 4, half-maximal inhibitory concentration: 42100 nM
Compound 4: the middle estimate sits 2.6-fold (0.42 log units) below what was measured, and the stated range ends below it.
By their numbers in this assay, from the lowest: compound 3; then compounds 4, 1 and 2 (each within the scatter of the next).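

In this assay, the change from 2-fluorophenyl to phenyl now has a pair of its own, a 2.9-fold higher number from compound 3 to compound 4 (0.46 log units; beyond the scatter), so with the 4-bromophenyl group in place, swapping fluoro for hydrogen on this aromatic carbon, ortho to a large group, moves the value beyond the scatter. The 4-bromophenyl group also proves to depend on its context: with phenyl it gives only a 1.2-fold lower number from compound 2 to compound 4 (0.09 log units; within the scatter), unlike the step beyond the scatter with 2-fluorophenyl, a 3.2-fold lower number from compound 1 to compound 3 (0.51 log units; beyond the scatter), although the chain replaced is nonyl in one case and heptyl in the other. Nothing available explains this step. As far as these compounds go, whether chloro or methoxy on this aromatic carbon would match fluoro remains open. So does whether fluoro matters when a saturated chain replaces the 4-bromophenyl group.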